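The compounds below may be only part of what the source reports. "The series", "measured", "known", "first", "only" and "open" are said of these compounds alone.

In an assay on artery for antagonist activity at transient receptor potential cation channel subfamily V member 1 (Rattus norvegicus), in the presence of a further agent that is not named here (a lower number here means that less compound is needed, a higher number that more compound is needed for the effect), compound 1 `CCCCC/C=C\C/C=C\C/C=C\C/C=C\CCCC(=O)Nc1ccc(OC)c(O)c1` gives 63.1 nM and compound 2 `CCCCC/C=C\C/C=C\C/C=C\C/C=C\CCCC(=O)Nc1ccc2[nH]ncc2c1` gives 398 nM.

Within the data shown here, compound 2 thus holds the higher of the two numbers; the only measured step, a 6.3-fold higher number from compound 1 to compound 2 (0.80 log units; beyond the scatter), lies between it and compound 1. Compound 3 `CCCCC/C=C\C/C=C\C/C=C\C/C=C\CCCC(=O)NCc1ccc2[nH]ncc2c1` differs from compound 2 by (1H-indazol-5-yl)methyl in place of 1H-indazol-5-yl on an amide-type nitrogen. Among the measured compounds shown here, that measured step concerns an exchange of the ring on the amide nitrogen, not the link to it, so no measured step bears on this change, and the expectation rests on compound 2 alone. Compound 3 is therefore expected to stay close to compound 2, a 1.5-fold higher number from compound 2 to compound 3 (0.18 log units; within the scatter), with a wide margin. The estimate for compound 3 in this assay is 600 nM, range 150 nM to 2500 nM.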

Compound 3, half-maximal effective concentration: 158 nM
Beside the measured number, compound 3's estimate is 3.8-fold (0.58 log units) above it; low and high end bracket the measured number.
By their numbers in this assay, from the lowest: compound 1; then compound 3; then compound 2.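

In this assay, the link to the amide-type nitrogen matters as well as the ring: (1H-indazol-5-yl)methyl in place of 1H-indazol-5-yl gives a 2.5-fold lower number from compound 2 to compound 3 (0.40 log units; beyond the scatter). This recovers only part of the loss seen with the indazole, since 3-hydroxy-4-methoxyphenyl still has the lowest number, with a 2.5-fold higher number from compound 1 to compound 3 (0.40 log units; beyond the scatter). Nothing at hand accounts for the shift.

Open, as far as these compounds go, is whether the same link would change the number for the other ring, as (3-hydroxy-4-methoxyphenyl)methyl. A longer link, as 2-(1H-indazol-5-yl)ethyl, would show whether the trend continues.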